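Propyl in Place of a Carbamate Chain on a Triazole Amine

This account rests on a few compounds, and the source may have more. Where it says the series, first, only, none or still open, it means among the compounds named here.

Compound 1 `CCCCC(O)Cn1cc(CN(C)CCC(C)C)nn1`: 47%
Compound 2 `CN(Cc1cn(CC(O)COC(=O)C2CCCCC2)nn1)CC1CCCCC1`: 18%
Compound 3 `CCCCNC(=O)OCC(O)Cn1cc(CN(C)CC2CCCCC2)nn1`: 12%

Three compounds sharing a triazole core carrying a tertiary amine have been measured in an assay on nucleic acid for inhibition of Nucleic Acid, read by fluorescence, tested at 100 uM; on this read-out lower numbers stand for less inhibition and higher numbers for more inhibition at the one concentration tested (going by the name of the read-out). Compound 3 gives 12%, the lowest of the three numbers; its nearest neighbour is compound 2 with 18%, and the gap between them is within the scatter, while compound 1 with 47% stands well beyond the scatter above compound 3.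

Compound 4 `CCCCC(O)Cn1cc(CN(C)CC2CCCCC2)nn1` has not yet been measured. It arises from compound 3 by one change: propyl in place of (butylcarbamoyl)oxy on a saturated chain carbon, two bonds along the chain from an oxygen on a saturated carbon. For the measured compounds named here, the only measured step, a number 6 percentage points lower from compound 2 to compound 3 (within the scatter), alters the same side chain at its carbonyl end and shows that exchanging the group on the carbonyl carbon changed little. That step does not remove the chain, so it only weakly bears on the present change. Going by the values given here, compound 1 carries the same hydroxy-bearing chain as compound 4 but a different amine; no step is given between compound 1 and compound 4, so its value can only hint that a shorter chain is compatible with a higher number.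

In this assay compound 4 is therefore expected to move upward, estimated as a number 18 percentage points higher from compound 3 to compound 4 (beyond the scatter), landing at 30% with a range from 10% to 50%.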

Compound 4, a percentage reported as inhibition, at one concentration (the size of the read-out at that concentration, not a potency): 47%
The estimate for compound 4 lay 17 percentage points below the measured number; the range from low to high includes it.
By their numbers in this assay, from the lowest: compounds 3 and 2 (each within the scatter of the next); then compounds 1 and 4 (each within the scatter of the next).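

In this assay, what sits at the end of this side chain counts for far more than the group on its carbonyl carbon. Propyl in place of (butylcarbamoyl)oxy gives a clear rise (a number 35 percentage points higher from compound 3 to compound 4 (beyond the scatter)), and propyl in place of (cyclohexylcarbonyl)oxy gives a similar one (a number 29 percentage points higher from compound 2 to compound 4 (beyond the scatter)), whereas exchanging only the group on the carbonyl carbon gave a small step (a number 6 percentage points lower from compound 2 to compound 3 (within the scatter)). With the short propyl-ended chain in place, cyclohexyl in place of isobutyl on the amine side makes no visible difference (no change at the digits printed from compound 1 to compound 4 (within the scatter)), so this read-out does not separate those two groups, and nothing measured here explains the rise on losing the carbonyl-bearing chain.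

These compounds cannot show whether the rise follows from removing the carbamate or ester link or simply from having a shorter chain, since both changed in the same step. Going by these compounds, it also remains open where a longer chain such as octyl, or a chain ending in an amine or a carboxylic acid, would fall, and each number comes from a single concentration, so none of them is a potency.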